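Fluorine Returns to the Amide Aryl Ring

The source may report more compounds than this note shows. Statements on the series, on what has been measured and on what is new or still open speak of the compounds shown alone.

Of the compounds shown here, three built on one shared core have been measured in a functional assay on HeLa cells (Homo sapiens) for antiproliferative activity, read by CCK-8 assay, with a stated time of 72 h; on this read-out lower numbers stand for stronger inhibition and higher numbers for weaker inhibition. Compound 1 `O=C(Nc1cccc(-c2oc3cc(-c4ccc(F)cc4)ccc3c(=O)c2O)c1)c1ccc(F)cc1` gives 5350 nM. Compound 2 `Cc1ccc(C(=O)Nc2cccc(-c3oc4cc(-c5ccc(F)cc5)ccc4c(=O)c3O)c2)cc1` gives 6190 nM. Compound 3 `O=C(Nc1cccc(-c2oc3cc(-c4ccc(F)cc4)ccc3c(=O)c2O)c1)c1ccc(Cl)cc1` gives 3670 nM. Compound 3 carries the lowest of the three numbers, yet its distance from the others is small: a 1.5-fold lower number from compound 1 to compound 3 (0.16 log units; within the scatter) and a 1.7-fold lower number from compound 2 to compound 3 (0.23 log units; within the scatter) both lie within the scatter, so the three compounds cannot be set apart on these data.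

Compound 4 `O=C(Nc1cccc(-c2oc3cc(-c4ccc(F)cc4)ccc3c(=O)c2O)c1)c1ccc(F)cc1F` is not yet measured. It differs from compound 3 by 2,4-difluorophenyl in place of 4-chlorophenyl on a carbonyl carbon. Going by the values given here, only one measured step bears directly on this move: a 1.5-fold lower number from compound 1 to compound 3 (0.16 log units; within the scatter), which is the reverse exchange, chloro in place of fluoro, and it stayed within the scatter. Among the compounds with values here, the second fluoro on the entering ring has no counterpart among the measured compounds, so nothing is known about its effect from these data. The expectation therefore rests on compound 1, which gives 5350 nM with a single fluoro on that ring. For compound 4 the expected value in this assay is 5000 nM, estimated to fall between 2500 nM and 10000 nM. The expected step is a 1.4-fold higher number from compound 3 to compound 4 (0.13 log units; within the scatter), which is no step beyond the scatter.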

Compound 4, half-maximal inhibitory concentration: 10700 nM
Compound 4: middle estimate off by 2.1-fold (0.33 log units), on the low side; the whole stated range lies below it.
By their numbers in this assay, from the lowest: compounds 3, 1, 2 and 4 (each within the scatter of the next, the first and the last beyond it).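

In this assay, the exchange of 4-chlorophenyl for 2,4-difluorophenyl on the carbonyl carbon gives the first step at this position that clears the scatter, a 2.9-fold higher number from compound 3 to compound 4 (0.46 log units; beyond the scatter), so the amide aryl ring is no longer silent among these compounds. Going by these compounds alone, that separation appears only between the two ends of the series, since the added fluoro alone, a 2.0-fold higher number from compound 1 to compound 4 (0.30 log units; within the scatter), stays within the scatter, as does the exchange of the 4-methylphenyl group, a 1.7-fold higher number from compound 2 to compound 4 (0.24 log units; within the scatter), and the single exchange of fluoro for chloro, a 1.5-fold lower number from compound 1 to compound 3 (0.16 log units; within the scatter), so the step beyond the scatter is reached only where the chloro is lost and a second fluoro is gained together. Nothing in the data offers an explanation for this step.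

The compounds shown leave open whether a second chloro on the ring of compound 3 would take the number in the opposite direction from the second fluoro. They also leave open how this assay would respond to an amine or a carboxylic acid in place of the fluoro of compound 1.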